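The source may hold more compounds than are shown below. What is called first, only, known or untested is meant among the compounds shown, and "the series" means these compounds.

Measured compounds and their values in the metabolic stability test:

Compound 1, `Cc1nc(NCCCNS(C)(=O)=O)nc2ccc(NC(=O)/C=C/c3ccc(OC(F)(F)F)cc3)cc12`, gives 58%.
Compound 2, `Cc1nc(N2CCC(O)(C3CC3)CC2)nc2ccc(NC(=O)COc3ccc(OC(F)(F)F)cc3)cc12`, gives 36%.
Compound 3, `C/C(=C\C(=O)Nc1ccc2nc(N3CCC(N4CCCC4=O)CC3)nc(C)c2c1)c1ccc(OC(F)(F)F)cc1`, gives 86%.

These numbers come from an ADME assay on microsomes from liver (Mus musculus) for metabolic stability, with a stated time of 30 min; a lower number here means that less of the compound is left, a higher number that more of the compound is left. Among the three, compound 1 stands second highest: compound 3 lies above it and compound 2 lies below it, and both of those gaps are beyond the usual scatter of repeated measurements, so the order between these three compounds is meaningful.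

The compound to be followed here is compound 4, `COCC(=O)NC1CCN(c2nc(C)c3cc(NC(=O)/C=C/c4ccc(OC(F)(F)F)cc4)ccc3n2)CC1`. It shares the core of compound 1 and differs at a single position: 4-(((methoxymethyl)carbonyl)amino)piperidin-1-yl in place of (3-(methanesulfonamido)propyl)amino on an aromatic carbon. Going by the values given here, no measured pair in this set shows exactly this change, so what it does has to be judged from the whole picture rather than from a known step.

The step of a number 6 percentage points higher from compound 1 to compound 4 (within the scatter) is expected to be modest and upward, possibly no larger than the scatter. Compounds carrying a piperidin-1-yl group at this position span a wide range: compound 3 gives 86% while compound 2 gives 36%, so the group itself settles little. Compound 4 is estimated at about 64%, within a range from 42% to 84%.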

Compound 4, percent of the compound remaining: 57%
Beside the measured number, compound 4's estimate is 7 percentage points above it, and the stated range covers the measured number.
By their numbers in this assay, from the lowest: compound 2; then compounds 4 and 1 (each within the scatter of the next); then compound 3.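

In this assay, going by these compounds alone, the exchange of (3-(methanesulfonamido)propyl)amino for 4-(((methoxymethyl)carbonyl)amino)piperidin-1-yl gives a number 1 percentage points lower from compound 1 to compound 4 (within the scatter) and so provides the first direct comparison at this position, on the aromatic carbon between two ring nitrogen atoms. The earlier compounds shown here could not show this, since each differed from the others in more than one place, whereas here the rest of the molecule stays fixed: a chain with no ring and a sulfur atom gives way to a group with a six-membered non-aromatic ring and no sulfur, with no difference that this test can separate from scatter. Nothing measured on these compounds explains why the two groups read alike.

This single pair cannot say whether the same holds for other groups at this position, such as a piperidine carrying a free primary amine or a carboxylic acid, or a morpholine ring. It also leaves open whether a longer chain ending in the same methanesulfonamide, or the same piperidine group on a different amide side of the core, would keep the reading where it is.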